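This account rests on a few compounds, and the source may have more. Where it says the series, first, only, none or still open, it means among the compounds named here.

In a functional assay with Oryctolagus cuniculus as the target (a higher number here means a weaker inhibitor, a lower number a stronger inhibitor), compound 1 `COc1ccc(-c2nc(CNC(=O)NC(C)C)sc2-c2ccc(OC)cc2)cc1` gives 42 nM. Compound 2 `COc1ccc(-c2nc(C(N)=O)sc2-c2ccc(OC)cc2)cc1` gives > 1000 nM, which is a limit of the assay and not a number. Compound 2 stands at the limit of > 1000 nM in this assay, at which 1 of the 2 values shown sits. Compound 3 `COc1ccc(-c2nc(C(=O)N(C)C)sc2-c2ccc(OC)cc2)cc1` differs from compound 2 by dimethylamino in place of amino on a carbonyl carbon, with dimethylamino in place of amino on a carbonyl carbon. Going by the values given here, only one measured step bears on this, and only indirectly: an at least 23-fold higher number from compound 1 to compound 2 (1.37 log units; beyond the scatter), where carbamoyl took the place of ((isopropylcarbamoyl)amino)methyl on an aromatic carbon. That step is large, but it does not test the new change on the carbonyl carbon. No step beyond the scatter is therefore expected in this assay, and no direction is favoured. The estimated step is a step that the limit leaves unreadable from compound 2 to compound 3. For compound 3, the expected value is 1300 nM, within an estimated range of 300 nM to 5000 nM.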

Compound 3, half-maximal inhibitory concentration: < 100 nM
Compound 3: a limit, no number (the forecaster's own chance of this, stated with the estimate: 60%); middle value at least 13-fold (1.11 log units) from the limit.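

In this assay, going by these compounds alone, the change on the carbonyl carbon itself gives an at least 10-fold lower number from compound 2 to compound 3 (1.00 log units; beyond the scatter), a step that the earlier compounds had not tested. Compound 3 gives < 100 nM, which is a limit of the assay and not a number. It also lacks the ((isopropylcarbamoyl)amino)methyl group of compound 1, so the loss in an at least 23-fold higher number from compound 1 to compound 2 (1.37 log units; beyond the scatter) does not show that this group is needed, since dimethylcarbamoyl at the same aromatic carbon restores a clear part of the lost inhibition.

Going by these compounds, the step between compound 1 and compound 3 cannot be read, so it stays open how the two compare. On these data alone, it also stays open whether methylamino or diethylamino on the same carbonyl carbon would behave like dimethylamino or like amino.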